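The source may hold more compounds than are shown below. What is called first, only, known or untested is meant among the compounds shown, and "the series" means these compounds.

In a functional assay (microsomes, liver) with Rattus norvegicus as the target (a lower number here means a stronger inhibitor, a higher number a weaker inhibitor), compound 1 `Cc1c(C)c2c(c(C)c1N)CC(C)(CSc1ccccc1)O2` gives 270 nM. Among the measured compounds shown here, that is the higher of the two numbers so far, and its gap to compound 2 `Cc1c(C)c2c(c(C)c1N)CC(C)(CN1CCC(c3ccccc3)CC1)O2` at 70 nM lies beyond the usual scatter. Compound 3 `Cc1c(C)c2c(c(C)c1N)CC(C)(CBr)O2` keeps the shared core but carries bromo in place of phenylsulfanyl on a saturated chain carbon bound to a saturated ring carbon. Compound 1 at 270 nM and compound 2 at 70 nM both hold an aromatic ring in this side group, whereas compound 3 has none, so a moderately weaker result is expected. The estimated step is a 2.2-fold higher number from compound 1 to compound 3 (0.35 log units; beyond the scatter). For compound 3 the expected value is 600 nM, with an estimated range of 150 nM to 2500 nM.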

Compound 3, half-maximal inhibitory concentration: 300 nM
For compound 3 the middle estimate is 2.0-fold (0.30 log units) above the measured one; measured number inside the range.
By their numbers in this assay, from the lowest: compound 2; then compounds 1 and 3 (each within the scatter of the next).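

In this assay, putting bromo in place of phenylsulfanyl on a saturated chain carbon bound to a saturated ring carbon gives a 1.1-fold higher number from compound 1 to compound 3 (0.05 log units; within the scatter). At this position, then, the aromatic ring of compound 1 can go without a change beyond the scatter, even though the group shrinks from 7 heavy atoms to 1.

From the compounds shown here alone, whether an amine or a carboxylic acid at this place would shift the number remains open. Compound 1 and compound 3 read alike. No evidence is available that bears on this result.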